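Adding a Second Trifluoromethyl Group to the Urea Ring

A few compounds are considered here, and "the series" means these few. Any claim that something is new, unique, unknown or untested is made for them only; others in the source may bear on it.

Compound 3, `COc1cc(-c2nn(-c3cccc(NC(=O)Nc4cccc(C(F)(F)F)c4)c3)cc2-c2ccncc2)ccc1Cl`, carries a urea linking the shared core to a phenyl ring bearing one trifluoromethyl group. In a functional assay on IGROV-1 cells (Homo sapiens) for inhibition, read by sulforhodamine B assay, with a stated time of 48 h (on this read-out lower numbers stand for stronger inhibition of growth and higher numbers for weaker inhibition of growth), compound 3 gives 1060 nM. Among the three measured compounds this places it second highest: compound 1, `COc1cc(-c2nn(-c3cccc(NC(=O)c4ccc(Cl)c(C(F)(F)F)c4)c3)cc2-c2ccncc2)ccc1Cl`, gives 2150 nM, and compound 2, `O=C(Nc1cccc(-n2cc(-c3ccncc3)c(-c3ccc(Cl)c(O)c3)n2)c1)Nc1cc(C(F)(F)F)cc(C(F)(F)F)c1`, gives 896 nM, the latter within the scatter of compound 3.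

Compound 4, `COc1cc(-c2nn(-c3cccc(NC(=O)Nc4cc(C(F)(F)F)cc(C(F)(F)F)c4)c3)cc2-c2ccncc2)ccc1Cl`, differs from compound 3 in a single place: trifluoromethyl in place of hydrogen on an aromatic carbon. Going by the values given here, the only measured step, a 2.0-fold lower number from compound 1 to compound 3 (0.31 log units; beyond the scatter), concerns the exchange of the whole aryl amide for a urea and so speaks to a different change. Compound 2 shares the two trifluoromethyl groups of compound 4 but carries a hydroxy group where compound 4 carries a methoxy group, so its value and that of compound 3 can only be compared directly, and they lie within the scatter of one another. No step beyond the scatter is therefore expected, and the estimated step is a 1.2-fold lower number from compound 3 to compound 4 (0.07 log units; within the scatter). Compound 4 is expected to give 900 nM, with a range from 450 nM to 1800 nM.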

Compound 4, concentration for 50% growth inhibition: 826 nM
Compound 4: middle estimate off by 1.1-fold (0.04 log units), on the high side; low and high end bracket the measured number.
By their numbers in this assay, from the lowest: compounds 4, 2 and 3 (each within the scatter of the next); then compound 1.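

In this assay, a second trifluoromethyl group on the urea ring, meta to the first, gives a 1.3-fold lower number from compound 3 to compound 4 (0.11 log units; within the scatter) and so stays within the scatter: this position takes the four extra heavy atoms without a clear gain or loss in growth inhibition. Going by these compounds alone, the new compound also gives the first reading at the oxygen on the aromatic ring, where methyl in place of hydrogen gives a 1.1-fold lower number from compound 2 to compound 4 (0.04 log units; within the scatter) and again stays within the scatter, so the hydroxy and methoxy forms cannot be told apart here. No measurement at hand explains either result.

Still open, as far as these compounds go, is what an amine or a carboxylic acid would do on this same carbon of the urea ring. Also open, from the compounds shown here alone, is whether a second trifluoromethyl group would behave alike on the amide series of compound 1.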